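From 4-chlorophenyl to 3-fluorophenyl on a sulfonyl sulfur

The compounds below may be only part of what the source reports. "The series", "measured", "known", "first", "only" and "open" are said of these compounds alone.

In a functional assay on LOX IMVI cells (Homo sapiens) for cytotoxicity, read by MTT assay, with a stated time of 24 h (on this read-out lower numbers stand for stronger inhibition and higher numbers for weaker inhibition), compound 3 (`O=S(=O)(NCCCNc1nccc(-c2[nH]c(-c3ccccc3)nc2-c2ccc(F)c(O)c2)n1)c1ccc(Cl)cc1`) gives 14200 nM as its reading. In this assay compound 2 (`O=S(=O)(NCCCNc1nccc(-c2[nH]c(-c3ccccc3)nc2-c2ccc(F)c(O)c2)n1)c1ccccc1`) gives 9580 nM as its reading, which lies within the scatter of compound 3. In this assay compound 1 (`COc1cc(-c2nc(-c3ccccc3)[nH]c2-c2ccnc(NCCCNS(=O)(=O)c3cccc(F)c3)n2)ccc1Cl`) gives 5110 nM as its reading, a lower number than compound 3 by more than the scatter.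

Compound 4 (`O=S(=O)(NCCCNc1nccc(-c2[nH]c(-c3ccccc3)nc2-c2ccc(F)c(O)c2)n1)c1cccc(F)c1`) has not yet been measured. For the measured compounds named here, it departs from compound 3 by 3-fluorophenyl in place of 4-chlorophenyl on a sulfonyl sulfur as its only change, which places 3-fluorophenyl in place of 4-chlorophenyl on a sulfonyl sulfur.

Going by the values given here, the only measured step at this group is a 1.5-fold higher number from compound 2 to compound 3 (0.17 log units; within the scatter) and represents chloro in place of hydrogen on an aromatic carbon, a step within the scatter. Compound 4 shares 3-fluorophenyl on a sulfonyl sulfur with compound 1, whose 5110 nM reading comes with a different core and is therefore only a loose guide. Among the compounds with values here, no measured pair isolates the exact exchange.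

The estimated change is a 1.4-fold lower number from compound 3 to compound 4 (0.15 log units; within the scatter) and is expected to stay within the scatter, with no firm direction. For compound 4 the expected value is 10000 nM in this assay and the estimated range runs from 4500 nM to 21000 nM for repeated measurements.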

Compound 4, half-maximal inhibitory concentration: 7890 nM
For compound 4 the middle estimate is 1.3-fold (0.10 log units) above the measured one, within the range that was stated.
By their numbers in this assay, from the lowest: compounds 1, 4, 2 and 3 (each within the scatter of the next, the first and the last beyond it).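

In this assay the exchange at the sulfonyl sulfur now has a direct reading, a 1.8-fold lower number from compound 3 to compound 4 (0.26 log units; within the scatter) and so stays within the scatter, while the step that adds fluoro to the phenyl of compound 2 reads a 1.2-fold lower number from compound 2 to compound 4 (0.08 log units; within the scatter) and is also within it. Taken with a 1.5-fold higher number from compound 2 to compound 3 (0.17 log units; within the scatter) these steps show that, among the phenyl, 4-chlorophenyl and 3-fluorophenyl groups on the sulfonyl sulfur of the shared core, no exchange moves the number beyond the scatter. Compound 4 also joins compound 1 through the shared 3-fluorophenyl, at a 1.5-fold higher number from compound 1 to compound 4 (0.19 log units; within the scatter) for 4-fluoro-3-hydroxyphenyl in place of 4-chloro-3-methoxyphenyl, so the gap between compound 1 and compound 3, which is beyond the scatter, now divides into steps that each lie within it.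

Going by these compounds, whether an amine or a carboxylic acid on the phenyl at the sulfonyl sulfur would carry the number beyond the scatter stays open, as does the separate share of the halogen and of its place on the ring, which change together in this exchange. Nothing available here gives a reason for any of these readings.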